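Cytotoxicity of a fluorophenyl amide against a non-cancer cell line

This account rests on a few compounds, and the source may have more. Where it says the series, first, only, none or still open, it means among the compounds named here.

Compound 1 `CCOc1ccc(NC(=O)c2cccc(/C=C3\CC(=O)N(Cc4ccccc4)C3=O)c2)cc1`, compound 2 `CCOc1ccc(NC(=O)c2cccc(/C=C3\CC(=O)N(c4ccccc4)C3=O)c2)cc1` and compound 3 `O=C(Nc1ccc(Cl)cc1)c1cccc(/C=C2\CC(=O)N(Cc3ccccc3)C2=O)c1` were all tested in an ADME assay on NCM460 cells (Homo sapiens) for cytotoxicity, read by MTT assay, with a stated time of 72 h; a lower number here means a stronger inhibitor, a higher number a weaker inhibitor. In this assay compound 1 gives > 100000 nM, a limit of the assay rather than a number. Compound 2 likewise reaches only a limit, > 100000 nM, in this assay. Compound 3 too gives a limit, > 100000 nM, in this assay. The step that the two limits leave unreadable from compound 1 to compound 2 and the step that the two limits leave unreadable from compound 1 to compound 3 therefore cannot be sized, because of the limit of > 100000 nM in this assay, at which 3 of the 3 values shown sit. Compound 2 thus stands at the limit shared by every value shown. Compound 4 `O=C(Nc1cccc(F)c1)c1cccc(/C=C2\CC(=O)N(c3ccccc3)C2=O)c1` differs from compound 2 by 3-fluorophenyl in place of 4-ethoxyphenyl on an amide-type nitrogen. No measured step bears on this change, and none of the shown steps was readable at all. The expectation is therefore a step of a number no higher from compound 2 to compound 4 (the limit leaves the size open), that is none beyond the scatter, with compound 4 most likely again reported only as a limit. Compound 4 is estimated at 100000 nM in this assay, within a range from 40000 nM to 250000 nM.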

Compound 4, half-maximal inhibitory concentration: > 100000 nM
Compound 4: no number, only a limit (the forecaster's own chance of this, stated with the estimate: 85%); the middle value sits exactly at the limit.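

The step between compound 2 and compound 4 cannot be read, as each is reported only as a limit in this assay: the limit of > 100000 nM in this assay, at which 4 of the 4 values shown sit.

The compounds shown leave open where any of them would reach a half-maximal effect in this assay, and whether any of these group changes alters it.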